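Branching the thioether chain: compound 2 to compound 3

A few compounds are considered here, and "the series" means these few. Any claim that something is new, unique, unknown or untested is made for them only; others in the source may bear on it.

Compound 1 `CC(C(=O)NCc1ccc(C(F)(F)F)cc1N1CCCCCCC1)c1ccc(NS(C)(=O)=O)c(F)c1` gives 2.8 nM in an assay on CHO cells for antagonist activity at transient receptor potential cation channel subfamily V member 1 (Homo sapiens), read by FLIPR; a higher number here means a weaker inhibitor, a lower number a stronger inhibitor. Compound 2 `CCCCSc1cc(C(F)(F)F)ccc1CNC(=O)C(C)c1ccc(NS(C)(=O)=O)c(F)c1` gives 1.9 nM in this assay. Going by the values given here, the step of a 1.5-fold lower number from compound 1 to compound 2 (0.17 log units; within the scatter) exchanges the whole substituent on that aromatic carbon, and the two numbers stand within the scatter of each other; on the numbers so far, compound 2 cannot be separated from compound 1. Compound 3 `CC(C)CCSc1cc(C(F)(F)F)ccc1CNC(=O)C(C)c1ccc(NS(C)(=O)=O)c(F)c1` differs from compound 2 by methyl in place of hydrogen on a saturated chain carbon bound to two saturated chain carbons, so the butyl thioether becomes an isopentyl thioether. Among the compounds with values here, the only measured step, a 1.5-fold lower number from compound 1 to compound 2 (0.17 log units; within the scatter), swaps a quite different group at this position without moving the number beyond the scatter; no measured pair tests branching within the chain itself. On that basis the step is expected to be a 1.2-fold higher number from compound 2 to compound 3 (0.06 log units; within the scatter), that is, no movement beyond the scatter. Compound 3 is therefore estimated at 2.2 nM in this assay, with a range from 0.8 nM to 6 nM.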

Compound 3, inhibition constant: 1.4 nM
The estimate for compound 3 lay 1.6-fold (0.20 log units) above the measured number; the measured number falls inside the stated range.
By their numbers in this assay, from the lowest: compounds 3, 2 and 1 (each within the scatter of the next).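

Branching within the thioether chain is now tested directly in this assay (a 1.4-fold lower number from compound 2 to compound 3 (0.13 log units; within the scatter)), and the butyl to isopentyl change leaves compound 3 inseparable from compound 2. The exchange of the whole substituent on that aromatic carbon also stays within the scatter (a 2.0-fold lower number from compound 1 to compound 3 (0.30 log units; within the scatter)), so the eight-membered ring group and the two thioether chains of compounds 1, 2 and 3 cannot be told apart at this position. Nothing in the data given here accounts for these results.

Still open, as far as these compounds go, is how far this position accepts change: a much shorter chain such as a methyl thioether, or a longer one such as an octyl thioether, could show where the number begins to move. Also open, from the compounds shown here alone, is whether a chain ending in an amine or a carboxylic acid stays within the scatter of compounds 1, 2 and 3.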